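Swapping the aryl arm for a small amide on the core

A few compounds are considered here, and "the series" means these few. Any claim that something is new, unique, unknown or untested is made for them only; others in the source may bear on it.

Measured compounds:
compound 1 `O=C(CCCCCCc1ccccc1)c1ncc(-c2cccc(C(=O)C(F)(F)F)c2)o1` gives 16 nM in an assay (Rattus norvegicus) for inhibition of Fatty-acid amide hydrolase 1 (Homo sapiens); on this read-out higher numbers stand for weaker inhibition and lower numbers for stronger inhibition
compound 2 `COC(=O)c1ccc(-c2cnc(C(=O)CCCCCCc3ccccc3)o2)cc1` gives 40 nM in this assay
compound 3 `COc1ccc(-c2cnc(C(=O)CCCCCCc3ccccc3)o2)cc1` gives 100 nM in this assay

Compound 3 stands at the highest number of the three measured compounds; compound 2 sits nearest, and compound 1 furthest, at lower numbers. Within the data shown here, the one measured step, a 2.5-fold higher number from compound 2 to compound 3 (0.40 log units; beyond the scatter), changes a group on the six-membered aromatic ring that hangs from the shared core.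

Compound 4 `CN(C)C(=O)c1cnc(C(=O)CCCCCCc2ccccc2)o1` is not yet measured. It differs from compound 3 by dimethylcarbamoyl in place of 4-methoxyphenyl on an aromatic carbon. Here the whole 4-methoxyphenyl, one six-membered aromatic ring, leaves, and the dimethylcarbamoyl with no ring enters in its place on the five-membered aromatic ring.

Among the measured compounds shown here, no measured step removes the six-membered ring, so the step from compound 2 to compound 3 speaks only indirectly: all three measured compounds carry that ring, and the largest spread among them arises from changes upon it. Losing it altogether is expected to move further than that spread, toward weaker inhibition. Compound 4 is therefore estimated at 400 nM, between 100 nM and 2000 nM, a step of a 4.0-fold higher number from compound 3 to compound 4 (0.60 log units; beyond the scatter).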

Compound 4, inhibition constant: 2 nM
For compound 4 the middle estimate is 200-fold (2.30 log units) above the measured one, and the stated range ends above it.
By their numbers in this assay, from the lowest: compound 4; then compound 1; then compound 2; then compound 3.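

In this assay, dimethylcarbamoyl in place of 4-methoxyphenyl gives a 50-fold lower number from compound 3 to compound 4 (1.70 log units; beyond the scatter). Among these compounds, all the earlier compounds carry a six-membered aromatic ring at this end of the molecule, and this result shows that such a ring is not needed on this carbon, next to the ring oxygen, for strong inhibition: a group with no ring can serve there, and far better than 4-methoxyphenyl does. Nothing shown here explains why this swap has so large an effect.

The compounds shown leave open which part of dimethylcarbamoyl matters, the carbonyl or the two methyl groups on its nitrogen. A carboxylic acid, an amide with no methyl groups on its nitrogen or a nitrile on this same carbon would help separate those two parts.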